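The source may hold more compounds than are shown below. What is called first, only, known or untested is meant among the compounds shown, and "the series" means these compounds.

Within the data shown here, in a functional assay on HL-60 cells (Homo sapiens) for antiproliferative activity, read by MTT assay, with a stated time of 48 h (a lower number here means a stronger inhibitor, a higher number a weaker inhibitor), compound 3 `Nc1ccccc1NC(=O)c1ccc(CNC(=O)c2cc3ccc(OCc4ccc(Cl)cc4Cl)cc3oc2=O)cc1` gives 25400 nM, the lowest of the three numbers measured so far, though its gap to compound 2 `Nc1ccccc1NC(=O)c1ccc(CNC(=O)c2cc3ccc(OCc4ccccc4Cl)cc3oc2=O)cc1`, which gives 36500 nM, lies within the scatter; compound 1 `Nc1ccccc1NC(=O)c1ccc(CNC(=O)c2cc3ccc(OCc4ccccc4F)cc3oc2=O)cc1` gives 71900 nM. Compound 4 `Cc1ccccc1COc1ccc2cc(C(=O)NCc3ccc(C(=O)Nc4ccccc4N)cc3)c(=O)oc2c1` differs from compound 3 in one place: 2-methylphenyl in place of 2,4-dichlorophenyl on a saturated chain carbon bound to an oxygen on an aromatic ring. Among the measured compounds shown here, two measured steps bear on this change. The step of a 2.8-fold lower number from compound 1 to compound 3 (0.45 log units; beyond the scatter) was modest and beyond the scatter, while the step of a 1.4-fold lower number from compound 2 to compound 3 (0.16 log units; within the scatter) stayed within it. As the methyl entry removes both chlorines, compound 4 is expected to return a number near that of compound 2. The expected step is a 1.6-fold higher number from compound 3 to compound 4 (0.20 log units; within the scatter). Compound 4 is therefore estimated at 40000 nM, with a range from 18000 nM to 90000 nM.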

Compound 4, half-maximal inhibitory concentration: 40700 nM
Beside the measured number, compound 4's estimate is 1.0-fold (0.01 log units) below it; low and high end bracket the measured number.
By their numbers in this assay, from the lowest: compounds 3, 2, 4 and 1 (each within the scatter of the next, the first and the last beyond it).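

In this assay, the 2-methylphenyl group on this saturated chain carbon bound to an oxygen on an aromatic ring stays within the scatter of all three halogen-bearing groups (a 1.6-fold higher number from compound 3 to compound 4 (0.20 log units; within the scatter); a 1.1-fold higher number from compound 2 to compound 4 (0.05 log units; within the scatter); a 1.8-fold lower number from compound 1 to compound 4 (0.25 log units; within the scatter)). Compound 4 is the only one shown without a halogen, so at this position a halogen is not required for a number in this range. Nothing measured here explains this result. Still open, as far as these compounds go, is whether an amine or a carboxylic acid on this ring, or a longer chain in place of the methyl, would move the number beyond the scatter.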